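A few compounds are considered here, and "the series" means these few. Any claim that something is new, unique, unknown or untested is made for them only; others in the source may bear on it.

Measured compounds:

Compound 1, `CNc1ncnc2c1c(I)cn2[C@@H]1O[C@H](CO)[C@@H](O)[C@H]1O` — > 100000 nM
Compound 2, `COc1ncnc2c1c(I)cn2[C@@H]1O[C@H](CO)[C@@H](O)[C@H]1O` — 63000 nM
Compound 3, `CNc1ncnc2c1c(-c1ccco1)cn2[C@@H]1O[C@H](CO)[C@@H](O)[C@H]1O` — 90800 nM

All three were tested in an ADME assay on MRC5 cells (Homo sapiens), read by MTT assay, with a stated time of 72 h; on this read-out lower numbers stand for stronger inhibition and higher numbers for weaker inhibition. For compound 1 the result > 100000 nM is a limit of the assay, not a number. Compound 2 differs from compound 1 by methoxy in place of methylamino on an aromatic carbon. In this assay compound 2 gives 63000 nM. The step is an at least 1.5-fold lower number from compound 1 to compound 2 (0.20 log units; that floor lies within the scatter); that size is only a floor, since compound 1 sits at the limit of > 100000 nM in this assay, at which 1 of the 3 values shown sits. Compound 3 differs from compound 1 by furan-2-yl in place of iodo on an aromatic carbon. In this assay compound 3 gives 90800 nM. The step is an at least 1.1-fold lower number from compound 1 to compound 3 (0.04 log units; that floor lies within the scatter). Compound 3 and compound 2 lie within the usual scatter of each other, so no order between them can be read.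

Compound 4, `COc1ncnc2c1c(-c1ccco1)cn2[C@@H]1O[C@H](CO)[C@@H](O)[C@H]1O`, has not been measured. It differs from compound 3 by methoxy in place of methylamino on an aromatic carbon, the same change that was made from compound 1 to compound 2, where it gave an at least 1.5-fold lower number from compound 1 to compound 2 (0.20 log units; that floor lies within the scatter); the two place descriptions agree word for word. The cores of the two pairs differ by furan-2-yl in place of iodo on an aromatic carbon. Since compound 1 gave only a limit, the measured step is a floor, and the expectation for compound 4 rests on that floor applied to compound 3. Compound 2, at 63000 nM, serves as a comparable point. The expected step is a 1.5-fold lower number from compound 3 to compound 4 (0.18 log units; within the scatter). Compound 4 is estimated at 60000 nM, with a likely range from 30000 nM to 120000 nM, which leaves room for the assay to report only a limit.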

Compound 4, half-maximal inhibitory concentration: 1700 nM
The estimate for compound 4 lay 35-fold (1.55 log units) above the measured number; measured number outside the range, below it.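

In this assay, methoxy in place of methylamino, with furan-2-yl on the core, gives a 53-fold lower number from compound 3 to compound 4 (1.73 log units; beyond the scatter), and furan-2-yl in place of iodo, with methoxy on the core, gives a 37-fold lower number from compound 2 to compound 4 (1.57 log units; beyond the scatter), so among the compounds shown the low number appears only where methoxy and furan-2-yl stand together. This does not show that the methoxy change differs in size between the two cores, nor that its size carries over from one core to the other: the same change on two cores in this assay, an at least 1.5-fold lower number (0.20 log units; that floor lies within the scatter) from compound 1 to compound 2 and a 53-fold lower number (1.73 log units; beyond the scatter) from compound 3 to compound 4; the limit leaves it open whether they differ. The same caution holds for the furan-2-yl change: the same change on two cores in this assay, an at least 1.1-fold lower number (0.04 log units; that floor lies within the scatter) from compound 1 to compound 3 and a 37-fold lower number (1.57 log units; beyond the scatter) from compound 2 to compound 4; the limit leaves it open whether they differ.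

Going by these compounds, whether an ethoxy group or an ethylamino group in place of methoxy would also give a number as low as that of compound 4 remains open. So does whether a thiophene or a phenyl ring in place of furan-2-yl would keep that number low in this assay.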